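The compounds below may be only part of what the source reports. "The series", "measured", "known", "first", "only" and "open" are said of these compounds alone.

Measured compounds and their numbers in an assay on HEK293 cells for inhibition of Voltage-dependent T-type calcium channel subunit alpha-1G (Homo sapiens), read by patch clamp; on this read-out lower numbers stand for stronger inhibition and higher numbers for weaker inhibition:

Compound 1, `CCCc1nc(-c2ccccc2)c(CNCCCN2CCN(c3ccc(F)cc3)CC2)o1`, gives 3210 nM.
Compound 2, `CCCc1nc(-c2ccccc2)c(CNCCCN2CCN(c3cccc(C(F)(F)F)c3)CC2)o1`, gives 650 nM.
Compound 3, `CCCc1nc(-c2ccccc2)c(CNCCCN2CCN(c3cccc(F)c3)CC2)o1`, gives 3030 nM.

Compound 3 stands second highest of these three numbers. Its nearest neighbour is compound 1: a 1.1-fold lower number from compound 1 to compound 3 (0.03 log units; within the scatter), so the two cannot be told apart. Its furthest neighbour is compound 2: a 4.7-fold higher number from compound 2 to compound 3 (0.67 log units; beyond the scatter).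

Compound 4, `CCCc1nc(-c2ccccc2)c(CNCCCN2CCN(c3cccc(Cl)c3)CC2)o1`, differs from compound 3 in one place: chloro in place of fluoro on an aromatic carbon. Going by the values given here, no measured pair shows exactly this change. The steps that come closest are the one where trifluoromethyl gave way to fluoro, a 4.7-fold higher number from compound 2 to compound 3 (0.67 log units; beyond the scatter), and the one where 3-(trifluoromethyl)phenyl replaced 4-fluorophenyl, a 4.9-fold lower number from compound 1 to compound 2 (0.69 log units; beyond the scatter), both modest and both pointing to fluoro as the weaker end. For chloro no such anchor exists, so in this assay only a small step is expected, more likely toward a lower number than a higher one: a 2.0-fold lower number from compound 3 to compound 4 (0.31 log units; beyond the scatter). Compound 4 is therefore estimated at 1500 nM, within a range from 500 nM to 4000 nM.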

Compound 4, half-maximal inhibitory concentration: 1750 nM
Estimate against measurement, compound 4: 1.2-fold (0.07 log units) below, within the range that was stated.
By their numbers in this assay, from the lowest: compound 2; then compounds 4, 3 and 1 (each within the scatter of the next).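

In this assay, chloro in place of fluoro on this aromatic carbon gives a 1.7-fold lower number from compound 3 to compound 4 (0.24 log units; within the scatter) and so makes no difference that can be read at this position. Going from 4-fluorophenyl to 3-chlorophenyl gives a 1.8-fold lower number from compound 1 to compound 4 (0.26 log units; within the scatter) and also separates nothing, which places compound 1, compound 3 and compound 4 together as one level of inhibition. Trifluoromethyl alone stays apart among the groups shown: chloro in its place gives a 2.7-fold higher number from compound 2 to compound 4 (0.43 log units; beyond the scatter) as a modest step, so chloro does not match it at this position.

Nothing here explains why trifluoromethyl differs from chloro and fluoro. Still open, going by these compounds, is whether other groups at this position, such as a methoxy group or a nitrile, would fall with compound 2 or with the other three.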